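Pyridin-2-yl to Phenyl on Two Related Cores

This account rests on a few compounds, and the source may have more. Where it says the series, first, only, none or still open, it means among the compounds named here.

Compound 1 `Oc1cccc(-c2cc(-c3ccc(Cl)cc3)nc(-c3ccccn3)c2)c1`: 13500 nM
Compound 2 `Oc1cccc(-c2cc(-c3ccccc3)nc(-c3ccc(Cl)cc3)c2)c1`: 8110 nM
Compound 3 `Oc1cccc(-c2cc(-c3ccccn3)nc(-c3ccccc3Cl)c2)c1`: "not determined" (no result reported)

In a functional assay on HCT-15 cells (Homo sapiens) for cytotoxicity, read by CCK-8 assay and cell counting, with a stated time of 2 days (on this read-out lower numbers stand for stronger inhibition and higher numbers for weaker inhibition), compound 1 gives 13500 nM and compound 2 gives 8110 nM. The change between them is phenyl in place of pyridin-2-yl on an aromatic carbon, and it produced a 1.7-fold lower number from compound 1 to compound 2 (0.22 log units; within the scatter). Compound 3 carries a different core, since it differs from compound 1 by 2-chlorophenyl in place of 4-chlorophenyl on an aromatic carbon, and in this assay compound 3 gives "not determined" (no result reported), so no number was obtained for it. Compound 4 `Oc1cccc(-c2cc(-c3ccccc3)nc(-c3ccccc3Cl)c2)c1` arises from compound 3 by phenyl in place of pyridin-2-yl on an aromatic carbon, the same kind of change as before, though here the place is meta to a 2-chlorophenyl group rather than meta to a 4-chlorophenyl group. With no value for compound 3, the expectation rests on compound 2 and its value 8110 nM, together with the small step already seen. Compound 4 is therefore expected to give about 10000 nM, within 3000 nM to 35000 nM.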

Compound 4, half-maximal inhibitory concentration: 2930 nM
Compound 4: middle estimate off by 3.4-fold (0.53 log units), on the high side; measured number below the stated range.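

Placing 2-chlorophenyl in place of 4-chlorophenyl gives a 2.8-fold lower number from compound 2 to compound 4 (0.44 log units; beyond the scatter) in this assay, so the two chlorophenyl groups do not give the same result when the rest of the molecule is phenyl-substituted. As far as these compounds go, the swap of pyridin-2-yl for phenyl can be read only as a 1.7-fold lower number from compound 1 to compound 2 (0.22 log units; within the scatter), while its counterpart from compound 3 to compound 4 cannot be read, as compound 3 has no number, so whether this swap carries over to the other core remains unknown. Nothing measured here explains the result.

All the compounds shown keep the 3-hydroxyphenyl group, so the effect of an amine or a carboxylic acid in place of its hydroxyl remains open. Also open, from the compounds shown here alone, is how a methyl group in place of the chlorine would compare.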